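The source may hold more compounds than are shown below. What is called first, only, known or untested is meant among the compounds shown, and "the series" means these compounds.

Working notes on the series in an ADME assay on HepG2 cells (Homo sapiens) for cytotoxicity; a lower number here means that less compound is tolerated, a higher number that more compound is tolerated. Compound 3 (`O=C(NC1CCC1)C1CN(c2ccccc2)CC(=O)N1c1ccc2ccsc2c1`) gives > 50000 nM, which is a limit of the assay and not a number. Compound 2 (`O=C(NCC1CC1)C1CN(c2ccccc2)CC(=O)N1c1ccc2ccsc2c1`) gives > 50000 nM, likewise a limit. The series thus shows (the limit of > 50000 nM in this assay, at which 2 of the 3 values shown sit). For the measured compounds named here, the one measured step at this place, a step that the two limits leave unreadable from compound 2 to compound 3, offers no size to carry forward.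

Going by the values given here, compound 1 (`O=C(NC1CCCC1)C1CN(c2ccc(C(F)(F)F)cc2)CC(=O)N1c1ccc2ccsc2c1`) gives 10000 nM, the only actual number so far. It already carries cyclopentyl on the amide-type nitrogen, but it also has a trifluoromethyl group that compound 2 and compound 3 lack, and the data do not separate the two features.

Compound 4 (`O=C(NC1CCCC1)C1CN(c2ccccc2)CC(=O)N1c1ccc2ccsc2c1`) is the next case: cyclopentyl in place of cyclobutyl on an amide-type nitrogen. In words, cyclopentyl stands in place of cyclobutyl on an amide-type nitrogen. No step beyond the scatter is expected, though any movement would more likely be toward a lower number, given compound 1 at 10000 nM. The expected change is an at least 1.2-fold lower number from compound 3 to compound 4 (0.09 log units; that floor lies within the scatter). A report of only a limit remains the likelier outcome. For compound 4 the estimated value is 40000 nM, with an expected range from 15000 nM to 80000 nM.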

Compound 4, half-maximal cytotoxic concentration: > 50000 nM
Compound 4: a limit, no number; the forecaster's own chance of this, stated with the estimate: 65%; middle value at least 1.2-fold (0.09 log units) away from the limit.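

Hydrogen in place of trifluoromethyl on an aromatic carbon gives an at least 5.0-fold higher number from compound 1 to compound 4 (0.69 log units; beyond the scatter), the first readable step of the series in this assay. For the compounds shown here, compound 1 and compound 4 share cyclopentyl on the amide-type nitrogen, so the measured number of compound 1 goes with the trifluoromethyl group and not with cyclopentyl alone, a separation that the earlier compounds could not give. The steps among compound 2, compound 3 and compound 4 cannot be read, and cyclopropylmethyl, cyclobutyl and cyclopentyl on the amide-type nitrogen remain untold apart: the limit of > 50000 nM in this assay, at which 3 of the 4 values shown sit.

From the compounds shown here alone, the size of the trifluoromethyl step remains a floor only, as compound 4 stands at a limit and not at a number, and whether the step would recur with cyclobutyl or cyclopropylmethyl on the amide-type nitrogen stays open. Also open, going by these compounds, is whether another group on that aromatic carbon, such as chlorine or a methoxy group, or a longer chain or an amine on the amide-type nitrogen, would bring a measured number in place of the limit.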